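This account rests on a few compounds, and the source may have more. Where it says the series, first, only, none or still open, it means among the compounds named here.

Compound 1 `CCCCc1ccc2c(c1)C(=O)C(=O)N2`: > 10000 nM, a limit of the assay
Compound 2 `COc1ccc(-c2ccc3c(c2)C(=O)C(=O)N3c2ccc(OC)cc2)cc1`: > 10000 nM, a limit of the assay
Compound 3 `COc1ccc(-c2ccc3c(c2)C(=O)C(=O)N3Cc2ccc(Cl)cc2)cc1`: 350 nM

All three compounds were tested in a functional assay on K562 cells (Homo sapiens) for antiproliferative activity, read by MTT assay, with a stated time of 48 h; on this read-out higher numbers stand for weaker inhibition and lower numbers for stronger inhibition. In this assay, going by the values given here, compound 3 gives the only actual number, 350 nM. Compound 1 and compound 2 give no number, only (the limit of > 10000 nM in this assay, at which 2 of the 3 values shown sit).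

Compound 4 `COc1ccc(-c2ccc3c(c2)C(=O)C(=O)N3Cc2cccc(OC)c2)cc1` has not yet been measured. It differs from compound 3 by one change: 3-methoxyphenyl in place of 4-chlorophenyl on a saturated chain carbon bound to an amide-type nitrogen in a ring. In words, 3-methoxyphenyl stands in place of 4-chlorophenyl on a saturated chain carbon bound to an amide-type nitrogen in a ring, which reads as 4-chlorobenzyl to 3-methoxybenzyl.

Among the compounds with values here, only one measured step bears on this place, and it is large: an at least 28-fold lower number from compound 2 to compound 3 (1.45 log units; beyond the scatter). That step replaced 4-methoxyphenyl with 4-chlorobenzyl on the nitrogen, whereas compound 4 keeps the saturated chain carbon that compound 3 carries. Within the data shown here, the step therefore gives no size for the present change, and no measured step covers this swap alone. The expected result is a 1.2-fold lower number from compound 3 to compound 4 (0.07 log units; within the scatter), with no size beyond the scatter and no direction favoured in this assay. For compound 4 the estimated value is 300 nM, with an expected range from 50 nM to 1500 nM.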

Compound 4, half-maximal inhibitory concentration: 680 nM
Estimate against measurement, compound 4: 2.3-fold (0.36 log units) below, and the stated range covers the measured number.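

In this assay, the change from 4-chlorobenzyl to 3-methoxybenzyl gives a 1.9-fold higher number from compound 3 to compound 4 (0.29 log units; within the scatter), so on this saturated chain carbon the two substituted phenyl groups cannot be told apart, even though chlorine leaves and a methoxy oxygen enters. The large gain over the 4-methoxyphenyl on the nitrogen of compound 2 now appears with two different groups on that chain carbon, as an at least 28-fold lower number from compound 2 to compound 3 (1.45 log units; beyond the scatter) and an at least 14-fold lower number from compound 2 to compound 4 (1.16 log units; beyond the scatter), and neither compound 3 nor compound 4 goes against it. Both of these steps remain bounds and not exact sizes because of the value at the compound 2 end: the limit of > 10000 nM in this assay, at which 2 of the 4 values shown sit.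

The pair does not separate the identity of the substituent from its place on the phenyl ring, since both changed together, and 4-methoxybenzyl or 3-chlorobenzyl would be needed to tell these apart. The compounds shown also leave open whether this position tolerates an unsubstituted benzyl, a pyridylmethyl group, a carboxylic acid or an amine on the ring, or a longer chain between the nitrogen and the ring.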